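The compounds below may be only part of what the source reports. "The series", "measured", "known", "first", "only" and "open" are said of these compounds alone.

Compound 1 `O=c1[nH]c(-c2cccc3ccccc23)nc2ccc(N3CCCCC3)cc12` is the anchor of this small set. In a functional assay on HeLa cells (Homo sapiens) for cytotoxicity, read by MTT assay, with a stated time of 2 days (a higher number here means a weaker inhibitor, a lower number a stronger inhibitor), compound 1 gives 330 nM, the lowest of the two numbers reported. Compound 3 `Cc1cccc(-c2nc3cc(C)ccc3c(=O)[nH]2)c1`, the nearest of them, gives 11200 nM in this assay, a gap from compound 1 that lies well beyond the usual scatter. Compound 2 `Cc1ccc2nc(-c3cccc(F)c3)[nH]c(=O)c2c1` is reported in this assay only as a limit, > 50000 nM, and not as a number; that is the limit of > 50000 nM in this assay, at which 1 of the 3 values shown sits. Among the compounds with values here, no two measured compounds differ in one place, so no single measured step can be read off here; what the numbers do show is that compound 2 and compound 3, both of which carry a methyl on the core, sit far weaker than compound 1.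

Compound 4 `Cc1ccc2nc(-c3cccc4ccccc34)[nH]c(=O)c2c1` has not been measured in this assay. It differs from compound 1 by methyl in place of piperidin-1-yl on an aromatic carbon, with the rest of compound 1 kept unchanged. The step from compound 1 to compound 4 is expected to be a loss in this assay, beyond the scatter, estimated as a 15-fold higher number from compound 1 to compound 4 (1.18 log units; beyond the scatter). This expectation rests on compound 3, which also carries a methyl and gives 11200 nM. Compound 4 is therefore estimated at 5000 nM, with a likely range from 1000 nM to 30000 nM.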

Compound 4, half-maximal inhibitory concentration: 5360 nM
Estimate against measurement, compound 4: 1.1-fold (0.03 log units) below; low and high end bracket the measured number.
By their numbers in this assay, from the lowest: compound 1; then compound 4; then compound 3. At a limit, above all of these: compound 2.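

In this assay, within the data shown here, the pair gives the first single-place comparison in this set: a 16-fold higher number from compound 1 to compound 4 (1.21 log units; beyond the scatter), a large step that comes from one change on an aromatic carbon, meta to a fused ring and para to a fused ring, with the rest of compound 1 kept. The earlier compounds shown here differed from compound 1 in more than one place, so they could not tie any of the gap to this position; this pair shows that the position alone matters strongly in this assay and that piperidin-1-yl here goes with the lower number, while methyl here still leaves compound 4 with a measured number rather than a limit. Nothing among the data shown accounts for the size of this step.

With only piperidin-1-yl and methyl at this place, the compounds shown leave open whether the lower number follows the ring itself or its nitrogen, a question that a morpholine, an open-chain dialkylamine or a primary amine at the same carbon would address. As far as these compounds go, it also remains open whether piperidin-1-yl would bring a step of similar size on compound 3.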